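The compounds below may be only part of what the source reports. "The series", "measured", "known", "first", "only" and "open" are said of these compounds alone.

The study so far contains two compounds measured in an assay on mitochondria from L6 cells (Rattus norvegicus) for activation, with a stated time of 90 min; a higher number here means that more compound is needed for the effect, a lower number that less compound is needed. Compound 1, `CCCCc1ccc(Nc2nc3nonc3nc2O)c(F)c1`, gives 1100 nM in this assay. Compound 2, `Oc1nc2nonc2nc1Nc1ccc(C(F)(F)F)cc1`, gives 10400 nM in this assay, the highest of the two numbers; its nearest neighbour is compound 1, whose number is lower by a margin beyond the usual scatter. Among the measured compounds shown here, no step between measured compounds that differ in a single place is available, so the pair of compound 1 and compound 2 shows only what its two values show. Compound 3, `Oc1nc2nonc2nc1Nc1ccc(C(F)(F)F)cc1F`, remains to be measured in this assay. It differs from compound 2 in one place: fluoro in place of hydrogen on an aromatic carbon. Compound 1 also carries a fluoro, but it differs from compound 2 in a second group as well, so the change is not isolated. The step from compound 2 to compound 3 is expected to be modest, toward a lower number, and possibly within the scatter, at a 1.7-fold lower number from compound 2 to compound 3 (0.24 log units; within the scatter). For compound 3 the expected value in this assay is 6000 nM, with a range from 2000 nM to 15000 nM.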

Compound 3, half-maximal effective concentration: 2600 nM
Compound 3: middle estimate off by 2.3-fold (0.36 log units), on the high side; measured number inside the range.
By their numbers in this assay, from the lowest: compound 1; then compound 3; then compound 2.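

In this assay, fluoro in place of hydrogen on an aromatic carbon, ortho to a large group and meta to a trifluoromethyl group, gives a 4.0-fold lower number from compound 2 to compound 3 (0.60 log units; beyond the scatter), so this single change moves the number beyond the scatter, which the pair of compound 1 and compound 2 could not show on its own. With the fluoro held in place, trifluoromethyl in place of butyl gives a 2.4-fold higher number from compound 1 to compound 3 (0.37 log units; beyond the scatter), so the butyl compound has the lower number in this one pair. Nothing at hand gives a reason for either step. The compounds shown leave open whether chloro or methoxy in place of that fluoro would lower the number as fluoro does. They also leave open how a propyl or hexyl chain in place of the butyl would compare.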